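The source may report more compounds than this note shows. Statements on the series, on what has been measured and on what is new or still open speak of the compounds shown alone.

For the measured compounds named here, in a functional assay on Maver1 cells (Homo sapiens) for inhibition, read by luminescence and CellTiter-Glo, with a stated time of 72 h (a lower number here means a stronger inhibitor, a higher number a weaker inhibitor), compound 1 (`CCOC(=O)c1cc(-c2ccc(Oc3ccccc3)cc2)nn1Cc1cccc(NC(=O)CCl)c1`) gives 500 nM and holds the lower of the two numbers measured so far. In this assay compound 2 (`O=C(CCl)Nc1cccc(Cn2nc(-c3ccc(Oc4ccccc4)cc3)cc2C(=O)O)c1`) gives 4700 nM as the higher number. Going by the values given here, the one measured step is a 9.4-fold higher number from compound 1 to compound 2 (0.97 log units; beyond the scatter) and it exchanges ethyl for hydrogen at the ester, which is not the place that changes next. Compound 3 (`CCOC(=O)c1cc(-c2ccc(Oc3ccccc3)cc2)nn1Cc1ccc(NC(=O)CCl)cc1`) keeps the ethyl ester and differs from compound 1 by 4-(((chloromethyl)carbonyl)amino)phenyl in place of 3-(((chloromethyl)carbonyl)amino)phenyl on a saturated chain carbon bound to an aromatic nitrogen with the same atoms joined differently. Among the compounds with values here, no measured step touches this place, so the data show no direction for it. Within the data shown here, that one step shows only that a single change on this core can reach beyond the scatter. A modest rise is expected, with a 3.0-fold higher number from compound 1 to compound 3 (0.48 log units; beyond the scatter) as the estimated step and a smaller change not excluded. For compound 3 the estimate is 1500 nM with an expected range from 350 nM to 6500 nM in this assay once measured.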

Compound 3, half-maximal inhibitory concentration: 400 nM
Estimate against measurement, compound 3: 3.8-fold (0.57 log units) above, within the range that was stated.
By their numbers in this assay, from the lowest: compounds 3 and 1 (each within the scatter of the next); then compound 2.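

In this assay, for the compounds shown here, the exchange of 3-(((chloromethyl)carbonyl)amino)phenyl for 4-(((chloromethyl)carbonyl)amino)phenyl gives a 1.3-fold lower number from compound 1 to compound 3 (0.10 log units; within the scatter) and so gives the first reading at this place, on a saturated chain carbon bound to an aromatic nitrogen. On the ethyl ester, the two groups cannot be told apart, while the change at the ester, a 9.4-fold higher number from compound 1 to compound 2 (0.97 log units; beyond the scatter) remains the only step beyond the scatter among the compounds shown. No available evidence bears on this result.

From the compounds shown here alone, whether the two groups would also read alike alongside the carboxylic acid of compound 2 remains open. Also open, going by these compounds, is what an acrylamide in place of the (chloromethyl)carbonyl amide, or a longer chain in place of the saturated chain carbon, would do to the number.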